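This account rests on a few compounds, and the source may have more. Where it says the series, first, only, none or still open, it means among the compounds named here.

Compound 1 `CCOc1ccc(C(O)C2OC(=O)c3c(OC)cc(OC)cc32)cc1` is the point of departure. In a functional assay on RAW264.7 cells (Mus musculus) for inhibition, read by Griess assay, with stated times of 1 h and 24 h (on this read-out lower numbers stand for stronger inhibition and higher numbers for weaker inhibition), compound 1 gives > 10000 nM, which is a limit of the assay and not a number. Compound 2 `C=CCCOc1ccc(C(O)C2OC(=O)c3c(OC)cc(OC)cc32)cc1` gives 1330 nM in this assay, so that an at least 7.5-fold lower number from compound 1 to compound 2 (0.87 log units; beyond the scatter). Compound 3 `COc1cc(OC)c2c(c1)C(C(O)c1ccc(OCc3ccccc3)cc1)OC2=O` gives > 10000 nM, also a limit. Compound 1 thus stands at the limit of > 10000 nM in this assay, at which 2 of the 3 values shown sit. Between them, a step that the two limits leave unreadable from compound 1 to compound 3, whereas an at least 7.5-fold higher number from compound 2 to compound 3 (0.87 log units; beyond the scatter). Compound 4 `COc1cc(OC)c2c(c1)C(C(O)c1ccc(OCC3CCCCC3)cc1)OC2=O` carries cyclohexyl in place of methyl on a saturated chain carbon bound to an oxygen on an aromatic ring. The step to compound 3 is the closest comparison, a larger group at the same place, and it ended at the limit. Compound 4 is therefore expected to give 7000 nM, within 1500 nM to 30000 nM, meaning an expected at least 1.4-fold lower number from compound 1 to compound 4 (0.15 log units; that floor lies within the scatter).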

Compound 4, half-maximal inhibitory concentration: > 10000 nM
Compound 4 was reported as a limit (the forecaster's own chance of this, stated with the estimate: 60%); middle value at least 1.4-fold (0.15 log units) away from the limit.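

A saturated ring at this place, cyclohexyl, ends at the same limit as the phenyl of compound 3, so neither ring group yields a number. Cyclohexyl in place of allyl gives an at least 7.5-fold higher number from compound 2 to compound 4 (0.87 log units; beyond the scatter), while the steps from compound 1 and from compound 3 to compound 4 cannot be read. The allyl of compound 2 thus remains the only group here with a number and not a limit: the limit of > 10000 nM in this assay, at which 3 of the 4 values shown sit.

The compounds shown leave open whether a longer chain ending in vinyl would also give a number. They also leave open whether an amine at the end of the chain would.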